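A few compounds are considered here, and "the series" means these few. Any claim that something is new, unique, unknown or untested is made for them only; others in the source may bear on it.

Compound 1, `COc1cc(-c2cc(/C=C/C(=O)c3ccc(N)cc3)[nH]n2)cc(OC)c1OC`, and compound 2, `COc1ccc(C(=O)/C=C/c2cc(-c3cc(OC)c(OC)c(OC)c3)n[nH]2)cc1`, share one core and differ only in the group carried by the aromatic ring that sits on the carbonyl carbon. In a functional assay on KM12 cells (Homo sapiens) for inhibition, read by sulforhodamine B assay, with a stated time of 48 h (a lower number here means a stronger inhibitor of growth, a higher number a weaker inhibitor of growth), compound 1 gives 1410 nM, and in this assay compound 2 gives 1560 nM. For the measured compounds named here, the single measured step, a 1.1-fold higher number from compound 1 to compound 2 (0.04 log units; within the scatter), puts a methoxy in place of an amino group on that ring, and the two numbers cannot be told apart. Compound 2 therefore holds the higher of the two numbers, yet it stands within the scatter of compound 1, so neither compound can be called the weaker inhibitor.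

Compound 3, `COc1cc(-c2cc(/C=C/C(=O)c3ccc(F)c(F)c3)[nH]n2)cc(OC)c1OC`, alters the same ring once more: 3,4-difluorophenyl in place of 4-methoxyphenyl on a carbonyl carbon. Going by the values given here, only one measured step, a 1.1-fold higher number from compound 1 to compound 2 (0.04 log units; within the scatter), bears on this place, and it moved the number by an amount within the scatter. Replacing the 4-methoxyphenyl group by the 3,4-difluorophenyl group on the carbonyl carbon is therefore expected to leave the number close to that of compound 2, with a 1.0-fold lower number from compound 2 to compound 3 (0.02 log units; within the scatter) expected to stay within the scatter. Compound 3 is estimated at 1500 nM in this assay, with a range from 500 nM to 4500 nM.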

Compound 3, concentration for 50% growth inhibition: 3060 nM
Compound 3: the middle estimate sits 2.0-fold (0.31 log units) below what was measured; measured number inside the range.
By their numbers in this assay, from the lowest: compounds 1, 2 and 3 (each within the scatter of the next, the first and the last beyond it).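

In this assay, for the compounds shown here, the earlier pair could not be told apart, but the 3,4-difluorophenyl group now gives the first step at this place that lies beyond the scatter, a 2.2-fold higher number from compound 1 to compound 3 (0.34 log units; beyond the scatter), so compound 3 is a modestly weaker inhibitor of growth than compound 1. Measured against the 4-methoxyphenyl group, the same replacement gives a 2.0-fold higher number from compound 2 to compound 3 (0.29 log units; within the scatter), and that pair stays inseparable, so the difference can be claimed only between the 4-aminophenyl and 3,4-difluorophenyl groups. The aromatic ring on the carbonyl carbon can therefore register a change in what it carries, though only a small one across these three groups, and nothing available here accounts for that change.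

These three compounds cannot show whether the modest gap comes from gaining the two fluorines or from losing the amino group, a question that a 4-fluorophenyl or a plain phenyl group at this place could help to separate. They also leave open how far the number would move with a group of another kind there, such as a carboxylic acid on the ring or a saturated cyclohexyl ring in place of the aromatic one.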